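Swapping Chloro for Fluoro on a Thiourea Series

The source may report more compounds than this note shows. Statements on the series, on what has been measured and on what is new or still open speak of the compounds shown alone.

Of the compounds shown here, three built on the shared core have been measured. Compound 1 `Cc1ccc(NC(=S)NC(=O)c2cn(-c3ccccc3)nc2-c2ccc(F)cc2)cc1` gives 2080 nM in a functional assay on A549 cells (Homo sapiens) for inhibition, read by CCK-8 assay, with a stated time of 48 h; a lower number here means a stronger inhibitor, a higher number a weaker inhibitor. Compound 2 `Cc1ccc(-c2nn(-c3ccccc3)cc2C(=O)NC(=S)Nc2ccc(Cl)cc2)cc1` gives 3170 nM in this assay, and compound 3 `O=C(NC(=S)Nc1ccc(Cl)cc1)c1cn(-c2ccccc2)nc1-c1ccc(Cl)cc1` gives 3150 nM. Within the data shown here, the only single-place step among them, a 1.0-fold lower number from compound 2 to compound 3 (0.00 log units; within the scatter), changes nothing beyond the scatter. In this assay compound 3 holds the second highest of the three numbers, with compound 2 at the same level and compound 1 within the scatter as well.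

Compound 4 `O=C(NC(=S)Nc1ccc(Cl)cc1)c1cn(-c2ccccc2)nc1-c1ccc(F)cc1` differs from compound 3 in one place: fluoro in place of chloro on an aromatic carbon. Among the measured compounds shown here, no measured step makes exactly this swap. The step from compound 2 to compound 3 concerns a different ring and is flat, which suggests that small changes at these outer positions matter little here. Compound 1 carries fluoro on that same ring together with methyl on the other, and gives 2080 nM. That number sits within the scatter of compound 3. The expected step is therefore a 1.1-fold lower number from compound 3 to compound 4 (0.02 log units; within the scatter), none beyond the scatter. Compound 4 is estimated at 3000 nM, with a range from 1500 nM to 6000 nM.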

Compound 4, half-maximal inhibitory concentration: 2990 nM
Compound 4: middle estimate off by 1.0-fold (0.00 log units), on the high side; low and high end bracket the measured number.
By their numbers in this assay, from the lowest: compounds 1, 4, 3 and 2 (each within the scatter of the next).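

Among these compounds, the first direct reading of fluoro in place of chloro on this ring is a 1.1-fold lower number from compound 3 to compound 4 (0.02 log units; within the scatter) in this assay, and fluoro in place of methyl at the same aromatic carbon gives a 1.1-fold lower number from compound 2 to compound 4 (0.03 log units; within the scatter). Methyl, chloro and fluoro, para to a large group, therefore read alike in compounds 2, 3 and 4. Chloro in place of methyl elsewhere in the molecule gives a 1.4-fold higher number from compound 1 to compound 4 (0.16 log units; within the scatter), and this change reads alike on two cores: the same change on two cores in this assay, a 1.0-fold lower number (0.00 log units; within the scatter) from compound 2 to compound 3 and a 1.4-fold higher number (0.16 log units; within the scatter) from compound 1 to compound 4, 1.4-fold (0.16 log units) apart, within the scatter of two such steps.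

On these data alone, whether an amine, a carboxylic acid or a longer chain at this position would move the number beyond the scatter stays open. All four compounds lie within the scatter of the next in order, so they do not yet show which part of the structure the number depends on.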